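Swapping the ring substituent: from methyl to nitro

The source may report more compounds than this note shows. Statements on the series, on what has been measured and on what is new or still open speak of the compounds shown alone.

The shared core carries an amide that links it to a benzene ring bearing one substituent. Compound 1 `COc1cc2c(cc1OC)C(CC(=O)Nc1ccc(Br)cc1)CC2` has bromo there and in a functional assay on the whole organism (strain Wistar) for inhibition, with Rattus norvegicus as the target, read by paw edema, with a stated time of 3 h, at a dose of 100 mg/kg (on this read-out higher numbers stand for more inhibition at the one dose given (going by the name of the read-out) and lower numbers for less inhibition), compound 1 gives 43.5%. Compound 2 `COc1cc2c(cc1OC)C(CC(=O)Nc1ccc(C)cc1)CC2` has methyl and in this assay compound 2 gives 34.8%, the lower of the two numbers, yet the change a number 8.7 percentage points lower from compound 1 to compound 2 (within the scatter) stays within the scatter, so the two compounds cannot be ranked. Compound 3 `COc1cc2c(cc1OC)C(CC(=O)Nc1ccc([N+](=O)[O-])cc1)CC2` is not yet measured; it differs from compound 2 by nitro in place of methyl on an aromatic carbon, on an aromatic carbon of a six-membered aromatic ring of carbon only, para to a large group. Within the data shown here, the only step that bears on this position is the one from bromo to methyl, and it was small. A step of similar size or none beyond the scatter is therefore expected for this assay, with an estimated change of a number 5.2 percentage points higher from compound 2 to compound 3 (within the scatter). Compound 3 is expected to give about 40%, between 25% and 55%.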

Compound 3, a percentage reported as inhibition, in the whole organism at one dose (the size of the read-out at that dose, not a potency): 37.7%
Estimate against measurement, compound 3: 2.3 percentage points above, and the stated range covers the measured number.
By their numbers in this assay, from the lowest: compounds 2, 3 and 1 (each within the scatter of the next).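

Replacing methyl with nitro gives a number 2.9 percentage points higher from compound 2 to compound 3 (within the scatter), and replacing bromo with nitro gives a number 5.8 percentage points lower from compound 1 to compound 3 (within the scatter). In this assay, bromo, methyl and nitro therefore cannot be ranked at this place on the ring, even though nitro brings hydrogen-bond acceptors that methyl lacks and is larger by heavy-atom count. No measurement is available to explain why these three groups read alike.

The compounds shown leave open whether an amine, a carboxylic acid or a longer chain at this place would shift the number beyond the scatter. They also leave open whether bromo, methyl and nitro would still read alike at other doses, since a single dose says nothing about potency.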